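Cytotoxicity Step from Compound 1 to Compound 4

The source may report more compounds than this note shows. Statements on the series, on what has been measured and on what is new or still open speak of the compounds shown alone.

Compound 1 `CCN(CC)c1cc2[nH]c(C3CCCCC3)nc2cc1NC(=O)c1cnccn1`: > 100 ug/mL
Compound 2 `CCOCCOC(=O)Nc1cc2nc(C3CCCCC3)[nH]c2cc1N(C)C`: > 100 ug/mL
Compound 3 `CCCOCC(=O)Nc1cc2nc(C3CCCCC3)[nH]c2cc1N(C)C`: < 50 ug/mL

Three compounds share the core of compound 1 and were read in an ADME assay on Vero cells (Chlorocebus sabaeus) for cytotoxicity, read by resazurin assay, with a stated time of 3 days; on this read-out lower numbers stand for stronger inhibition and higher numbers for weaker inhibition. Compound 1 gives only a limit there, > 100 ug/mL, not a number. Compound 2 likewise sits at a limit, > 100 ug/mL. Compound 3 alone sits at the other limit, < 50 ug/mL. Two of the three values rest at the limit of > 100 ug/mL in this assay, at which 2 of the 3 values shown sit, and one at the limit of < 50 ug/mL in this assay, at which 1 of the 3 values shown sits, so compound 1 stands with the weaker-inhibiting pair.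

Compound 4 `CCCC(C)OC(=O)Nc1cc2nc(C3CCCCC3)[nH]c2cc1N(CC)CC` differs from compound 1 in one place: 1-methylbutoxy in place of pyrazin-2-yl on a carbonyl carbon. Among the measured compounds shown here, the single measured step, an at least 2.0-fold lower number from compound 2 to compound 3 (0.30 log units; that floor lies within the scatter), also alters the group on that carbonyl carbon, swapping an oxygen-linked chain for a carbon-linked one; its floor lies within the scatter, so it points to no clear direction. Compound 4 keeps an oxygen-linked chain on the carbonyl, as compound 2 does, and compound 2 stays at its limit. Compound 4 is therefore expected to give 100 ug/mL, between 50 ug/mL and 200 ug/mL, which is expected to mean a number no higher from compound 1 to compound 4 (the limit leaves the size open), a step within the scatter.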

Compound 4, half-maximal inhibitory concentration: > 100 ug/mL
Compound 4: no number, only a limit (the forecaster's own chance of this, stated with the estimate: 70%); the middle value sits exactly at the limit.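

Compound 1 and compound 4 both give only a limit, not a number, so no step between them can be read: the limit of > 100 ug/mL in this assay, at which 3 of the 4 values shown sit.

The compounds shown leave open whether 1-methylbutoxy in place of pyrazin-2-yl on a carbonyl carbon changes the read-out at all, and by how much.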